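Adding 4-methylpiperazin-1-yl to compound 1

This account rests on a few compounds, and the source may have more. Where it says the series, first, only, none or still open, it means among the compounds named here.

Going by the values given here, in a functional assay on MDA-MB-231 cells (Homo sapiens) for cytotoxicity, read by MTT assay, with a stated time of 72 h (a higher number here means a weaker inhibitor, a lower number a stronger inhibitor), compound 1 (`COc1ccc(Cn2nc(-c3ccccc3)c3cc(C(=N)Nc4ccccc4)ncc32)cc1`) gives 5400 nM, the lowest of the two numbers measured so far. Compound 2 (`N=C(Nc1ccccc1)c1cc2c(-c3ccccc3)n[nH]c2cn1`) gives 11000 nM. Among the compounds with values here, the one measured step, a 2.0-fold higher number from compound 1 to compound 2 (0.31 log units; beyond the scatter), puts hydrogen in place of 4-methoxybenzyl on an aromatic nitrogen and is modest.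

Compound 3 (`COc1ccc(Cn2nc(-c3ccccc3)c3cc(C(=N)Nc4ccc(N5CCN(C)CC5)cc4)ncc32)cc1`) keeps the 4-methoxybenzyl group and differs from compound 1 elsewhere: 4-methylpiperazin-1-yl in place of hydrogen on an aromatic carbon. This places 4-methylpiperazin-1-yl in place of hydrogen on an aromatic carbon of a six-membered aromatic ring of carbon only, para to a large group. Within the data shown here, no measured step touches this place, so the series offers no direct evidence on direction. The step of a 2.0-fold higher number from compound 1 to compound 2 (0.31 log units; beyond the scatter) serves only as a rough guide to size, at a different place in the structure. A modest step towards a lower number in this assay is tentatively expected, though a step the other way cannot be excluded. The estimated change is a 1.8-fold lower number from compound 1 to compound 3 (0.26 log units; within the scatter). For compound 3 the expected value is 3000 nM, with an estimated range of 800 nM to 10000 nM.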

Compound 3, half-maximal inhibitory concentration: 1760 nM
For compound 3 the middle estimate is 1.7-fold (0.23 log units) above the measured one; the range from low to high includes it.
By their numbers in this assay, from the lowest: compound 3; then compound 1; then compound 2.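

The para place on the six-membered aromatic ring of carbon only now has a measured direction: in this assay, 4-methylpiperazin-1-yl in place of hydrogen on an aromatic carbon gives a 3.1-fold lower number from compound 1 to compound 3 (0.49 log units; beyond the scatter). Going by these compounds alone, the only earlier step, a 2.0-fold higher number from compound 1 to compound 2 (0.31 log units; beyond the scatter), concerned the 4-methoxybenzyl group on an aromatic nitrogen and said nothing about this place, whereas the new step shows that a ring-bearing group of this size can enter here with the number going down rather than up. No accompanying measurement bears on the origin of this step, so it stands as an observation only.

From the compounds shown here alone, it remains open whether the step depends on the whole 4-methylpiperazin-1-yl group or would also appear with a simpler amine such as dimethylamino, with morpholin-4-yl, which replaces the methyl-bearing nitrogen with an oxygen, or with a carboxylic acid at the same place. Also open, going by these compounds, is whether 4-methylpiperazin-1-yl would give a step of similar direction and size on compound 2, where hydrogen stands in place of 4-methoxybenzyl.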